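Cytotoxicity series: amide to amine on the aromatic nitrogen

A few compounds are considered here, and "the series" means these few. Any claim that something is new, unique, unknown or untested is made for them only; others in the source may bear on it.

Measured compounds:
compound 1 `Cn1ncc([N+](=O)[O-])c1C(=O)Nc1ccc2nc(NC(=O)C3CCCCC3)sc2c1`, 0.026 ug/mL
compound 2 `O=C(Nc1ccc2nc(NC(=O)C3CCCCC3)sc2c1)c1cccc(F)c1`, 0.64 ug/mL
compound 3 `CC(C)CC(=O)Nc1nc2ccc(NC(=O)c3c(Cl)cccc3Cl)cc2s1`, 0.012 ug/mL

In a functional assay on WI-38 VA13 cells (Homo sapiens) for cytotoxicity (on this read-out lower numbers stand for an effect already at smaller amounts and higher numbers for an effect only at larger amounts of compound), compound 3 gives the lowest of the three numbers; compound 1 sits closest, compound 2 furthest. Compound 4 `O=C(Nc1ccc2nc(NCC3CCCCC3)sc2c1)c1c(Cl)cccc1Cl` is not yet measured. Its difference from compound 3: cyclohexylmethyl in place of isobutylcarbonyl on a nitrogen on an aromatic ring. The only measured step, a 25-fold higher number from compound 1 to compound 2 (1.39 log units; beyond the scatter), concerns the group on the carbonyl carbon on the other side of the shared core; no measured pair changes the group on the aromatic nitrogen, so nothing shown bears directly on this change. The expectation for compound 4 therefore rests on compound 3 alone, with a somewhat higher number judged likelier than a lower one: a 5.0-fold higher number from compound 3 to compound 4 (0.70 log units; beyond the scatter). Compound 4 is estimated at 0.06 ug/mL, range 0.012 ug/mL to 0.3 ug/mL in this assay.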

Compound 4, half-maximal effective concentration: 4.3 ug/mL
Compound 4: the middle estimate sits 72-fold (1.86 log units) below what was measured; measured number above the stated range.
By their numbers in this assay, from the lowest: compound 3; then compound 1; then compound 2; then compound 4.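

Within the data shown here, this is the first measured change on the nitrogen on an aromatic ring, and it is large: a 360-fold higher number from compound 3 to compound 4 (2.55 log units; beyond the scatter) in this assay. With the group on the carbonyl carbon held constant, (isobutylcarbonyl)amino to (cyclohexylmethyl)amino takes the series from its lowest number to its highest. No supporting data bear on the size of this step.

The step combines loss of the carbonyl with a change to a cyclohexyl-bearing group, and the compounds shown do not separate the two. Cyclohexylcarbonyl or plain isobutyl on this nitrogen, with the rest of compound 3 unchanged, would separate them.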